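Hydrazone aryl variation on the shared core

The source may report more compounds than this note shows. Statements on the series, on what has been measured and on what is new or still open speak of the compounds shown alone.

Compound 1 `CN(C)CCn1cnnc1-c1cc(Oc2ccc(NC(=O)N/N=C/c3c(Cl)cccc3Cl)cc2F)ccn1` and compound 2 `CN(C)CCn1cnnc1-c1cc(Oc2ccc(NC(=O)N/N=C/c3ccc(O)cc3)cc2F)ccn1` differ only in the aryl group on the hydrazone carbon. In a functional assay on HT-29 cells (Homo sapiens) for cytotoxicity, read by MTT assay, with a stated time of 72 h (on this read-out higher numbers stand for weaker inhibition and lower numbers for stronger inhibition), compound 1 gives 280 nM and compound 2 gives 1920 nM, so compound 2 holds the highest number of the two, with a 6.9-fold higher number from compound 1 to compound 2 (0.84 log units; beyond the scatter). Compound 3 `CN(C)CCn1cnnc1-c1cc(Oc2ccc(NC(=O)N/N=C/c3cccc(O)c3)cc2F)ccn1` carries 3-hydroxyphenyl in place of 4-hydroxyphenyl on a carbon with a double bond to nitrogen. Going by the values given here, no measured step moves the hydroxyl between ring positions, so the one step seen does not bear directly on this change, and no step beyond the scatter is expected. Compound 3 is estimated at 1500 nM (range 500 nM to 4500 nM), a step of a 1.3-fold lower number from compound 2 to compound 3 (0.11 log units; within the scatter) expected from compound 2.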

Compound 3, half-maximal inhibitory concentration: 330 nM
The estimate for compound 3 lay 4.5-fold (0.66 log units) above the measured number, outside the stated range (below it).
By their numbers in this assay, from the lowest: compounds 1 and 3 (each within the scatter of the next); then compound 2.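

With the same atoms joined differently, a 5.8-fold lower number from compound 2 to compound 3 (0.76 log units; beyond the scatter) appears in this assay from 3-hydroxyphenyl in place of 4-hydroxyphenyl, so the arrangement of this aryl group matters at this carbon. The step of a 1.2-fold higher number from compound 1 to compound 3 (0.07 log units; within the scatter) stays within the scatter, so a hydroxyl on the aryl group does not by itself give the higher number of compound 2, and compound 3 goes against that reading. No evidence at hand accounts for the difference between the two hydroxyphenyl groups.

On these data alone, whether the hydroxyl hydrogen is needed remains open, and 3-methoxyphenyl or 3-aminophenyl on the same carbon would test this.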